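The compounds below may be only part of what the source reports. "The series", "measured", "known", "first", "only" and "open" are said of these compounds alone.

For the measured compounds named here, in an assay on CHO cells for inhibition of Glucagon receptor (Homo sapiens), tested at 20 uM (on this read-out lower numbers stand for less inhibition and higher numbers for more inhibition at the one concentration tested (going by the name of the read-out)), compound 2 `CCCCCc1c(C(C)C)nc(C(C)C)c(CO)c1-c1ccccc1OC` gives 27%, while the only other measured compound, compound 1 `CCCCCc1c(C(C)C)nc(C(C)C)c(CO)c1-c1ccc(C(C)C)cc1`, gives 34%; the step of a number 7 percentage points lower from compound 1 to compound 2 (within the scatter) lies within the scatter, so these two numbers cannot be told apart. Compound 3 `CCCCCc1c(C(C)C)nc(C(C)C)c(CO)c1-c1ccc(Cl)cc1Cl` differs from compound 2 in one place: 2,4-dichlorophenyl in place of 2-methoxyphenyl on an aromatic carbon. Going by the values given here, the single measured step, a number 7 percentage points lower from compound 1 to compound 2 (within the scatter), also exchanges this aryl group and stayed within the scatter, so in this assay no step beyond the scatter is expected here either. The expected step is a number 3 percentage points higher from compound 2 to compound 3 (within the scatter). Compound 3 is therefore estimated at 30%, between 12% and 50%.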

Compound 3, a percentage reported as inhibition, at one concentration (the size of the read-out at that concentration, not a potency): 8%
Beside the measured number, compound 3's estimate is 22 percentage points above it, and the stated range ends above it.
By their numbers in this assay, from the lowest: compound 3; then compounds 2 and 1 (each within the scatter of the next).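

Exchanging the aryl group at this position, opposite the ring nitrogen, can move the number after all. With 2,4-dichlorophenyl in place of 2-methoxyphenyl, this assay shows a number 19 percentage points lower from compound 2 to compound 3 (beyond the scatter), and in place of 4-isopropylphenyl it shows a number 26 percentage points lower from compound 1 to compound 3 (beyond the scatter); the earlier pair alone stayed within the scatter. Nothing measured here explains this drop. Still open, on these data alone, is whether a phenyl with a single chlorine would give the same lower number, since both chlorines enter together. Also open, as far as these compounds go, is how a phenyl carrying an amine or a carboxylic acid would read at this position.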